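The compounds below may be only part of what the source reports. "The series", "measured", "known", "first", "only" and "open" are said of these compounds alone.

Compounds measured in an assay on cells for activation of probable G-protein coupled receptor 34 (Mus musculus), with a stated time of 1 h; a higher number here means a larger maximal response, a lower number a smaller maximal response:

- compound 1 `N[C@@H](COP(=O)(O)OCCCOC(=O)CCc1ccccc1OCCCCOc1ccccc1)C(=O)O` gives 0.033
- compound 2 `N[C@@H](COP(=O)(O)OCCCOC(=O)CCc1ccccc1OCc1cccc(OC2CCCCC2)c1)C(=O)O` gives 0.11
- compound 3 `N[C@@H](COP(=O)(O)OCCCOC(=O)CCc1ccccc1OCc1cccc(Oc2ccccc2Cl)c1)C(=O)O` gives 0.069

Compound 3 stands second highest of the three, but all three lie within the scatter of one another: its nearest neighbour is compound 1, and the gap to compound 2 is also within the scatter, so no order among them can be claimed.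

Compound 4 `N[C@@H](COP(=O)(O)OCCCOC(=O)CCc1ccccc1OCc1cccc(Oc2ccc(F)cc2)c1)C(=O)O` is the next compound. It differs from compound 3 in one place: 4-fluorophenyl in place of 2-chlorophenyl on an oxygen on an aromatic ring

For the measured compounds named here, the only measured step at this oxygen is a number 0.041 lower from compound 2 to compound 3 (within the scatter), where a ring of a different kind was exchanged and the intrinsic activity did not move beyond the scatter. Going by the values given here, no measured step exchanges one substituted phenyl for another, so there is no direct precedent for the step to compound 4. Among the compounds with values here, since the one exchange at this oxygen left this assay unmoved, the expected step a number 0.0010 higher from compound 3 to compound 4 (within the scatter) is none beyond the scatter. Compound 4 is therefore expected to give about 0.07, within a range from 0.03 to 0.13.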

Compound 4, intrinsic activity: the largest response reached, as a fraction of the reference agonist's: 0.66
Compound 4: the middle estimate sits 0.59 below what was measured; the measured number lies above the stated range.
By their numbers in this assay, from the lowest: compounds 1, 3 and 2 (each within the scatter of the next); then compound 4.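

At this oxygen on an aromatic ring, the attached group can decide the maximal response in this assay: exchanging 2-chlorophenyl for 4-fluorophenyl gives a number 0.59 higher from compound 3 to compound 4 (beyond the scatter) and exchanging cyclohexyl for 4-fluorophenyl gives a number 0.55 higher from compound 2 to compound 4 (beyond the scatter), whereas the earlier exchange at the same oxygen gave only a number 0.041 lower from compound 2 to compound 3 (within the scatter). The position therefore tolerates exchanges with no clear effect in one case and responds strongly in others, and two phenyl rings of equal heavy-atom count can read very differently here. Nothing available accounts for this difference.

The step to compound 4 changes both the halogen and the name-position of the substituent on the phenyl ring, so the two changes cannot be separated. Going by these compounds, how 4-chlorophenyl, 2-fluorophenyl or unsubstituted phenyl would read on this oxygen remains open.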